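This account rests on a few compounds, and the source may have more. Where it says the series, first, only, none or still open, it means among the compounds named here.

Compound 1, `CCCCC(O)c1cccc(NC(=O)NC(=O)CC)c1`, in a functional assay on HT-29 cells (Homo sapiens) for antiproliferative activity, with a stated time of 48 h (a lower number here means a stronger inhibitor, a higher number a weaker inhibitor), gives > 100000 nM, which is a limit of the assay and not a number.
Compound 2, `CCCCC(OC)c1cccc(NC(=O)NC(=O)CC)c1`, in this assay gives > 100000 nM, again a limit.
Compound 3, `CCCCC(O)c1cccc(NC(=O)CCCCl)c1`, in this assay gives > 100000 nM, also a limit.

Compound 2 differs from compound 1 by methyl in place of hydrogen on an oxygen on a saturated carbon. The step that the two limits leave unreadable from compound 1 to compound 2 stays hidden because the limit of > 100000 nM in this assay, at which 3 of the 3 values shown sit, covers both ends of it. Compound 3 differs from compound 1 by 3-chloropropyl in place of propanoylamino on a carbonyl carbon, and the step that the two limits leave unreadable from compound 1 to compound 3 is hidden for the same reason, since the limit of > 100000 nM in this assay, at which 3 of the 3 values shown sit, holds there too.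

Compound 4, `CCCCC(OC)c1cccc(NC(=O)CCCCl)c1`, is the one still to be measured. Within the data shown here, it differs from compound 3 by methyl in place of hydrogen on an oxygen on a saturated carbon, the same change as the one from compound 1 to compound 2, at the same place. That earlier change left compound 2 at the limit, as compound 1 was, so the expected step is a step that the limit leaves unreadable from compound 3 to compound 4 in this assay. The expectation rests on compound 3 sitting at > 100000 nM, a limit. Compound 4 is therefore estimated at 150000 nM, with a likely span from 50000 nM to 500000 nM, and most probably it will again give only a limit.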

Compound 4, half-maximal inhibitory concentration: > 100000 nM
Compound 4 gave a limit, no number (the forecaster's own chance of this, stated with the estimate: 85%); the middle value is on the limit's open side.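

No step to compound 4 can be read, either from compound 3 or from compound 2, because all the compounds sit at the same limit of the assay and give no number: the limit of > 100000 nM in this assay, at which 4 of the 4 values shown sit.

The compounds shown leave open whether hydroxy to methoxy, or the change on the carbonyl carbon, has any effect at all in this assay.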